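A few compounds are considered here, and "the series" means these few. Any claim that something is new, unique, unknown or untested is made for them only; others in the source may bear on it.

Measured compounds:

Compound 1 `O=C(NCCCCl)Oc1ccc(Cl)cc1C(=O)Nc1ccc(Cl)c(Cl)c1`. In a physicochemical assay for solubility, read by spectrophotometry (on this read-out higher numbers stand for higher solubility and lower numbers for lower solubility), compound 1 gives < 50000 nM, which is a limit of the assay and not a number.
Compound 2 `CCCNC(=O)Oc1ccc(Cl)cc1C(=O)Nc1ccc(Cl)c(Cl)c1`. In this assay compound 2 gives < 50000 nM, again a limit of the assay.
Compound 3 `O=C(NCCCCl)Oc1ccc(Cl)cc1C(=O)Nc1ccc(C(=O)c2ccccc2)cc1`. In this assay compound 3 gives < 50000 nM, also a limit of the assay.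

Compound 2 differs from compound 1 by hydrogen in place of chloro on a saturated chain carbon, three bonds along the chain from an amide-type nitrogen. The step this change made in this assay is a step that the two limits leave unreadable from compound 1 to compound 2, which is unreadable because of the limit of < 50000 nM in this assay, at which 3 of the 3 values shown sit. Compound 3 shares the carbamate side of compound 1, but how the two cores differ is not broken down here. Compound 4 `CCCNC(=O)Oc1ccc(Cl)cc1C(=O)Nc1ccc(C(=O)c2ccccc2)cc1` is not yet measured; it differs from compound 3 by hydrogen in place of chloro on a saturated chain carbon, three bonds along the chain from an amide-type nitrogen, the same change that turns compound 1 into compound 2, made at the same place. Since every measured value sits at a limit, the step from compound 3 to compound 4 in this assay is expected to be a step that the limit leaves unreadable from compound 3 to compound 4, resting only on compound 3 giving < 50000 nM. Compound 4 is therefore estimated at 20000 nM, between 4000 nM and 50000 nM.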

Compound 4, solubility: < 50000 nM
Compound 4 gave a limit, no number (the forecaster's own chance of this, stated with the estimate: 75%); the middle value is on the limit's open side.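

No size can be read for the change from compound 3 to compound 4, or for the matching change from compound 1 to compound 2, because the results give no numbers to compare: the limit of < 50000 nM in this assay, at which 4 of the 4 values shown sit. The compounds shown leave open where each truly falls in this assay, and whether going from 3-chloropropyl to propyl shifts the result at all.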